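The compounds below may be only part of what the source reports. "The series", "measured", "known", "first", "only" and "open" are said of these compounds alone.

Working notes on the series. Two compounds have been run in a physicochemical assay for lipophilicity, measured as octanol-water partition (on this read-out higher numbers stand for higher lipophilicity and lower numbers for lower lipophilicity), so far: compound 1 `C=CCOc1c(Cl)cc(N/C=N/OCC)cc1Cl` and compound 2 `C#CCc1c(Cl)cc(N/C=N/OC(C)C)cc1Cl`. In this assay compound 1 gives 4.3. In this assay compound 2 gives 3.9, the lower of the two numbers, with compound 1 sitting above it by a gap beyond the scatter. The two structures differ in more than one place, so that gap is not assigned to any single change.

Compound 3 `C#CCc1c(Cl)cc(N/C=N/OC/C=C\Cl)cc1Cl` is the next member and has not yet been measured in this assay. It is reached from compound 2 by one change: 3-chloroprop-2-en-1-yl in place of isopropyl on an oxygen. The isopropoxy group becomes (3-chloroprop-2-en-1-yl)oxy; the rest of the molecule is unchanged. Among the measured compounds shown here, no measured pair in the set shows this exchange, so the expectation rests on the counted change alone. The expected step is a modest rise, a number 0.50 log units higher from compound 2 to compound 3 (beyond the scatter), beyond the scatter but not large. Compound 3 is accordingly estimated at 4.4, with a range from 4 to 4.8.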

Compound 3, partition coefficient: 3.9
For compound 3 the middle estimate is 0.50 log units above the measured one; the whole stated range lies above it.
By their numbers in this assay, from the lowest: compounds 2 and 3 (each within the scatter of the next); then compound 1.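

In this assay, among the compounds shown here, 3-chloroprop-2-en-1-yl in place of isopropyl on an oxygen gives no change at the digits printed from compound 2 to compound 3 (within the scatter), and this is the first step that can be read at a single place. At this position, a group of 4 heavy atoms carrying a chlorine and a double bond outside aromatic rings therefore reads the same, within the scatter, as a group of 3 carbon heavy atoms, so the added chlorine and double bond together do not separate the two compounds on this read-out. Nothing in hand accounts for this result or shows how the two differences contribute individually.

Going by these compounds, it remains open whether a longer chain such as hexyl, or a chain ending in a carboxylic acid or an amine, on the same oxygen would also stay within the scatter of compound 2. On these data alone, it is equally open whether the same exchange would give a comparable step on the core of compound 1, and whether the chlorine and the double bond would each read differently if present alone.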